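A few compounds are considered here, and "the series" means these few. Any claim that something is new, unique, unknown or untested is made for them only; others in the source may bear on it.

Among the measured compounds shown here, compound 3 `CCOCc1cc(Br)c(O)c(O)c1Br` is the one member of this small series with a number in a functional assay on HCT-116 cells (Homo sapiens) for cytotoxicity, read by MTT assay, with a stated time of 96 h; a higher number here means a weaker inhibitor, a lower number a stronger inhibitor. In this assay compound 3 gives 1540 nM. Its companions have no result in this assay: compound 1 `O=Cc1cc(Br)c(O)c(O)c1Br` stands at "not determined" (no result reported), and compound 2 `CCCOCc1cc(O)c(O)c(Br)c1` stands at "not determined" (no result reported), so there is nothing to set against compound 3. Compound 4 `CCCOCc1cc(Br)c(O)c(O)c1Br` has not yet been tested in this assay. It differs from compound 3 by methyl in place of hydrogen on a saturated chain carbon, two bonds along the chain from an oxygen on a saturated carbon. With no measured step of this kind in the series, compound 4 is expected to sit close to compound 3, the step of a 1.1-fold lower number from compound 3 to compound 4 (0.04 log units; within the scatter) being estimated to remain within the usual scatter, with no clear direction. Compound 4 is therefore expected to give about 1400 nM, estimated to fall between 600 nM and 3500 nM.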

Compound 4, half-maximal inhibitory concentration: 800 nM
The estimate for compound 4 lay 1.8-fold (0.24 log units) above the measured number; measured number inside the range.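

In this assay, the series now holds one measured step at this position, a 1.9-fold lower number from compound 3 to compound 4 (0.28 log units; within the scatter). Methyl in place of hydrogen on this saturated chain carbon, which turns ethoxy into propoxy, therefore gives no difference that can be told from the scatter. Nothing shown gives a measured property that bears on this result. The compounds shown leave open whether a longer chain on the same oxygen would move the number beyond the scatter. They also leave open what an amine or a carboxylic acid at the end of this chain would do.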